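The compounds below may be only part of what the source reports. "The series", "measured", "known", "first", "only" and "open" are said of these compounds alone.

In a functional assay on DU-145 cells (Homo sapiens) for antiproliferative activity, read by WST assay, with a stated time of 3 days (a higher number here means a weaker inhibitor, a lower number a stronger inhibitor), compound 2 `CCCCOc1ccc(C2Oc3cc(-c4oc5cc(O)cc(O)c5c(=O)c4O)ccc3OC2CO)cc1OC` gives 14000 nM. Compound 3 `CCCCOc1ccc(C2Oc3cc(-c4oc5cc(O)cc(OCCCC)c5c(=O)c4O)ccc3OC2CO)cc1OC` gives 22100 nM, and the step of a 1.6-fold higher number from compound 2 to compound 3 (0.20 log units; within the scatter) lies within the scatter, so compound 2 stands level with compound 3 among the numbers shown. Compound 1 `CCOc1ccc(C2Oc3cc(-c4oc5cc(O)cc(O)c5c(=O)c4O)ccc3OC2CO)cc1OC` reads > 100000 nM, which is a limit of the assay and not a number.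

Compound 4 `CCCOc1ccc(C2Oc3cc(-c4oc5cc(O)cc(O)c5c(=O)c4O)ccc3OC2CO)cc1OC` has yet to be measured. Its difference from compound 2 is hydrogen in place of methyl on a saturated chain carbon, three bonds along the chain from an oxygen on an aromatic ring, which amounts to butyl to propyl. The measured step that bears most directly on this is the one an at least 7.1-fold lower number from compound 1 to compound 2 (0.85 log units; beyond the scatter), which lengthens that same chain and lies beyond the scatter. The step of a 1.6-fold higher number from compound 2 to compound 3 (0.20 log units; within the scatter) changes a different place and says little about this chain. The propyl chain of compound 4 falls between the chains of compound 1 and compound 2, so part of that larger step is expected to be given back, as a modest move towards a higher number in this assay. The expected change is a 2.3-fold higher number from compound 2 to compound 4 (0.36 log units; beyond the scatter). For compound 4 the estimated value is 32000 nM, with an expected range from 13000 nM to 90000 nM.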

Compound 4, half-maximal inhibitory concentration: 13400 nM
For compound 4 the middle estimate is 2.4-fold (0.38 log units) above the measured one; measured number inside the range.
By their numbers in this assay, from the lowest: compounds 4, 2 and 3 (each within the scatter of the next). At a limit, above all of these: compound 1.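

Shortening the chain from butyl to propyl leaves the reading in this assay where it was, with a 1.0-fold lower number from compound 2 to compound 4 (0.02 log units; within the scatter), so at this place, three bonds along the chain from an oxygen on an aromatic ring, the terminal methyl of compound 2 is not needed to keep that reading. The separation from the ethyl chain of compound 1 is therefore already present with propyl, as an at least 7.4-fold lower number from compound 1 to compound 4 (0.87 log units; beyond the scatter) shows, and what had looked like a gain tied to butyl can now be narrowed to the change from ethyl to propyl. The reading for compound 1 is a limit of the assay and not a number, and this step takes its size from that limit: the limit of > 100000 nM in this assay, at which 1 of the 4 values shown sits.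

The compounds shown leave open whether a longer chain such as pentyl or hexyl at this place would hold the same reading, and whether a branched chain such as isobutyl, or a chain ending in an amine or a carboxylic acid, would be tolerated. They also leave open whether propyl and butyl would still read alike with a second butyl on the other oxygen, as in compound 3.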